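The source may hold more compounds than are shown below. What is called first, only, known or untested is meant among the compounds shown, and "the series" means these compounds.

Compound 1 `Nc1nc(Cl)nc2c1ncn2C1C(O)C(O)[C@@]2(COP(=O)(O)OP(=O)(O)OP(=O)(O)O)C[C@@H]12`: 1900 nM
Compound 2 `Nc1nc(Cl)nc2c1ncn2[C@@H]1O[C@H](COP(=O)(O)OP(=O)(O)OP(=O)(O)O)[C@@H](O)[C@H]1O`: 2300 nM

Both numbers come from a functional assay for agonist activity at P2Y purinoceptor 2 (Homo sapiens), read by inositol phosphate accumulation; a lower number here means that less compound is needed, a higher number that more compound is needed for the effect. Compound 1 has the lowest of the two numbers, but compound 2 sits within the scatter of it, so the two cannot be told apart on these data.

Compound 3 `CNc1ncnc2c1ncn2C1C(O)C(O)[C@@]2(COP(=O)(O)OP(=O)(O)OP(=O)(O)O)C[C@@H]12` has not yet been measured. It differs from compound 1 in one place: a group of 11 heavy atoms (6 carbon, 5 nitrogen; one five-membered aromatic ring with 2 hetero atoms, one six-membered aromatic ring with 2 hetero atoms) in place of a group of 11 heavy atoms (5 carbon, 5 nitrogen, 1 chlorine; one five-membered aromatic ring with 2 hetero atoms, one six-membered aromatic ring with 2 hetero atoms), on a saturated ring carbon. For the measured compounds named here, no step between two measured compounds covers a change of this kind, so nothing measured here shows how much the chlorine-bearing group matters or what the methyl-bearing group brings. The expectation is therefore a modest shift to a higher number, beyond the usual scatter but not by much, resting on compound 1 with its 1900 nM as the starting point. Compound 3 is expected to give about 4000 nM in this assay, with a range from 1500 nM to 12000 nM. That estimate means an expected step of a 2.1-fold higher number from compound 1 to compound 3 (0.32 log units; beyond the scatter) toward a higher number.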

Compound 3, half-maximal effective concentration: 197 nM
Compound 3: middle estimate off by 20-fold (1.31 log units), on the high side; the measured number lies below the stated range.
By their numbers in this assay, from the lowest: compound 3; then compounds 1 and 2 (each within the scatter of the next).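

In this assay, putting the methyl-bearing group in place of the chlorine-bearing group on the saturated ring carbon brings a 9.6-fold lower number from compound 1 to compound 3 (0.98 log units; beyond the scatter) in this single step, so the number clearly depends on which of these groups sits at this position. Both groups have the same counts of heavy atoms, hydrogen-bond donors and hydrogen-bond acceptors, so those counts alone do not follow the shift. Nothing available here explains the change in the number.

Going by these compounds, the step combines losing the chlorine with gaining the methyl, so their separate contributions remain unknown, and a group carrying both the chlorine and the methyl, or neither, would be needed to pull them apart. On these data alone, whether an ethyl in place of the methyl, or a bromine in place of the chlorine, would move the number also remains open.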